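Pyridin-3-yl in place of 2-cyanophenyl on the shared core

This account rests on a few compounds, and the source may have more. Where it says the series, first, only, none or still open, it means among the compounds named here.

Compound 1 `CCCc1cccnc1Nc1cccc(C)n1` and compound 2 `CCOc1cc(-c2ccccc2C#N)cnc1Nc1cccc(C)n1` were tested in an assay on Ltk cells with metabotropic glutamate receptor 5 (Homo sapiens) as the target, read by fluorescence and calcium flux; on this read-out lower numbers stand for stronger inhibition and higher numbers for weaker inhibition. Compound 1 gives 394 nM, while compound 2 gives 37 nM, the lowest of the two numbers, and its distance from compound 1 lies beyond the scatter. Compound 3 `CCOc1cc(-c2cccnc2)cnc1Nc1cccc(C)n1` has not been measured; it differs from compound 2 by pyridin-3-yl in place of 2-cyanophenyl on an aromatic carbon. For the measured compounds named here, no measured pair shows this exchange, so the direction rests on guesswork. A modest weakening is expected, with the estimated step being a 2.4-fold higher number from compound 2 to compound 3 (0.39 log units; beyond the scatter). Compound 3 is expected to give about 90 nM in this assay, within 30 nM to 300 nM.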

Compound 3, half-maximal inhibitory concentration: 12 nM
Compound 3: middle estimate off by 7.5-fold (0.88 log units), on the high side; the measured number lies below the stated range.
By their numbers in this assay, from the lowest: compound 3; then compound 2; then compound 1.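

At the aromatic carbon para to the (6-methylpyridin-2-yl)amino group, the nitrile-bearing ring is not needed: in this assay pyridin-3-yl in place of 2-cyanophenyl gives a 3.1-fold lower number from compound 2 to compound 3 (0.49 log units; beyond the scatter) and so improves on compound 2. A six-membered aromatic ring with one ring nitrogen, and fewer heavy atoms, is therefore accepted at this carbon. Nothing measured here accounts for the step.

Whether the ring nitrogen or the loss of the nitrile drives this step stays open, since plain phenyl does not appear among these compounds. Going by these compounds, how pyridin-4-yl or pyridin-2-yl would compare at this carbon also remains unknown.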